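This account rests on a few compounds, and the source may have more. Where it says the series, first, only, none or still open, it means among the compounds named here.

Compound 1 `S=C(NCc1ccccc1)N1CCN(c2ncccn2)CC1` carries a pyrimidin-2-yl group on an amine nitrogen in a ring, and in a toxicity assay on RAW264.7 cells (Mus musculus) for cytotoxicity, read by MTT assay, with a stated time of 24 h (a higher number here means that more compound is tolerated, a lower number that less compound is tolerated), compound 1 gives 50900 nM. Compound 2 `O=C(C1CCCO1)N1CCN(C(=S)NCc2ccccc2)CC1` has (oxolan-2-yl)carbonyl in that place. In this assay compound 2 reaches only a limit of the assay, >= 200000 nM. The step of an at least 3.9-fold higher number from compound 1 to compound 2 (0.59 log units; beyond the scatter) is therefore itself a bound, resting on (the limit of >= 200000 nM in this assay, at which 1 of the 2 values shown sits). Compound 3 `CCCCN1CCN(C(=S)NCc2ccccc2)CC1` differs from compound 2 by butyl in place of (oxolan-2-yl)carbonyl on an amine nitrogen in a ring. Going by the values given here, no measured step involves a butyl group, and the only known step starts from a limit, so the expectation is loose. Compound 3 is expected to give about 100000 nM, between 30000 nM and 200000 nM. That estimate means a step of an at least 2.0-fold lower number from compound 2 to compound 3 (0.30 log units; that floor lies within the scatter) is expected.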

Compound 3, half-maximal cytotoxic concentration: >= 200000 nM
Compound 3 was reported as a limit; the forecaster's own chance of this, stated with the estimate: 30%; middle value at least 2.0-fold (0.30 log units) away from the limit.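

In this assay compound 3 gives a limit of the assay rather than a number, as compound 2 does, so two very different groups on this ring nitrogen, one with a ring and one without, both reach that limit. Putting butyl in place of pyrimidin-2-yl gives an at least 3.9-fold higher number from compound 1 to compound 3 (0.59 log units; beyond the scatter), and only compound 1 of the three has a measured number. The step between compound 2 and compound 3 cannot be read: the limit of >= 200000 nM in this assay, at which 2 of the 3 values shown sit.

Going by these compounds, whether a carboxylic acid or an amine on a longer chain at this nitrogen would also reach the limit stays open. On these data alone, how far the true values of compound 2 and compound 3 lie beyond it also stays open.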